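From compound 2 to compound 4: a large drop expected

The source may hold more compounds than are shown below. What is called first, only, known or untested is meant among the compounds shown, and "the series" means these compounds.

Compound 1 `CCCCOC(=O)c1cccc(NC(=O)c2cccc(-c3cc(C(=O)Nc4ccncc4F)ccc3CN)c2)c1` gives < 0.0834 h (a limit)
Compound 2 `NCc1ccc(C(=O)Nc2ccncc2F)cc1-c1cccc(C(=O)Nc2cccc(CC(=O)O)c2)c1` gives > 2 h (a limit)
Compound 3 `NCc1ccc(C(=O)Nc2ccncc2F)cc1-c1cccc(C(=O)OCC2CCCO2)c1` gives < 0.0834 h (a limit)

In an ADME assay on a cell-free system (plasma, Homo sapiens) for metabolic stability, read by LC-MS (on this read-out lower numbers stand for a shorter-lived compound and higher numbers for a longer-lived compound), compound 2 stands at > 2 h as a limit and not as a number. It alone sits at this long-lived end (the limit of > 2 h in this assay, at which 1 of the 3 values shown sits), and the other two compounds sit at the opposite end (the limit of < 0.0834 h in this assay, at which 2 of the 3 values shown sit).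

Compound 4 `CCCOC(=O)c1ccc(NC(=O)c2cccc(-c3cc(C(=O)Nc4ccncc4F)ccc3CN)c2)cc1` differs from compound 2 in one place, with 4-(propoxycarbonyl)phenyl in place of 3-(carboxymethyl)phenyl on an amide-type nitrogen. Among the compounds with values here, two measured steps bear on this change. The closer one (an at least 23-fold higher number from compound 1 to compound 2 (1.37 log units; beyond the scatter)) is an exchange of the same kind run in reverse, with carboxymethyl entering where butoxycarbonyl leaves. The other (an at least 23-fold lower number from compound 2 to compound 3 (1.37 log units; beyond the scatter)) also takes away the carboxymethyl-bearing group, with (oxolan-2-yl)methoxy on the carbonyl carbon instead. Both steps are large and beyond the scatter, and in both the compound without carboxymethyl lies at the short-lived end. Compound 4 also lacks carboxymethyl, so a large step toward a shorter half-life is expected in this assay. The expected step is an at least 28-fold lower number from compound 2 to compound 4 (1.45 log units; beyond the scatter) in size. Compound 4 is estimated at 0.07 h with a range from 0.03 h to 0.25 h and will probably be reported only as a limit.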

Compound 4, half-life: > 2 h
Compound 4 ended at the assay's limit; the forecaster's own chance of this, stated with the estimate: 80%; middle value at least 28-fold (1.45 log units) away from the limit.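

Compound 2 and compound 4 both stand at the long-lived limit of the half-life read-out, and the step between them cannot be read: the limit of > 2 h in this assay, at which 2 of the 4 values shown sit.

The compounds shown leave open how far past that limit each one lasts, and whether 4-(propoxycarbonyl)phenyl and 3-(carboxymethyl)phenyl on the amide-type nitrogen differ at all in half-life.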